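The compounds below may be only part of what the source reports. "The series", "measured", "known", "first", "only" and "open" are said of these compounds alone.

Measured so far:
compound 1 `O=Cc1ccc(OCc2ccc3no[n+]([O-])c3c2)cc1` (60000 nM)
compound 2 `N=C(N/N=C/c1ccc(O)cc1)SCc1ccc2no[n+]([O-])c2c1` (142000 nM)

In an ADME assay on J774 cells (Mus musculus) for cytotoxicity, read by MTT assay, with a stated time of 48 h (a lower number here means a stronger inhibitor, a higher number a weaker inhibitor), the two measured compounds sit apart by more than the usual scatter. Compound 1 holds the lower number of the pair (60000 nM), and compound 2 reads higher (142000 nM).

Compound 3 `NC(=S)N/N=C/c1ccc(OCc2ccc3no[n+]([O-])c3c2)cc1` has not yet been measured. It keeps the core of compound 1 but loses the formyl, para to a large group on an aromatic carbon. In its place stands a group of 6 heavy atoms (2 carbon, 3 nitrogen, 1 sulfur; no ring), a change counted as (a group of 6 heavy atoms (2 carbon, 3 nitrogen, 1 sulfur; no ring) in place of a group of 2 heavy atoms (1 carbon, 1 oxygen; no ring), on an aromatic carbon).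

For the measured compounds named here, no two measured compounds differ in one place only, so no measured step guides the size of this one, and the expectation has to stay broad. A modest move towards a lower number in this assay is expected, though a result within the scatter of the starting value would not surprise. That expected move is estimated as (a 1.3-fold lower number from compound 1 to compound 3 (0.12 log units; within the scatter)). The estimate for compound 3 is (45000 nM), with an expected range from (12000 nM) to (170000 nM).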

Compound 3, half-maximal inhibitory concentration: 400000 nM
Compound 3: middle estimate off by 8.9-fold (0.95 log units), on the low side, and the stated range ends below it.
By their numbers in this assay, from the lowest: compound 1; then compound 2; then compound 3.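

In this assay, putting the group of 6 heavy atoms (2 carbon, 3 nitrogen, 1 sulfur) in place of the formyl, on an aromatic carbon para to a large group, gives a 6.7-fold higher number from compound 1 to compound 3 (0.82 log units; beyond the scatter) on the core of compound 1. For the compounds shown here, this is the first single-place step, and it shows that what stands at this position can move the number clearly. In this one case, the larger entering group, with its 2 hydrogen-bond donors, goes with the weaker reading and not the stronger one, and no supporting measurement accounts for the shift.

The compounds shown leave open which part of the entering group goes with the step, and whether the same group with oxygen in place of its sulfur would read like compound 3. They also leave open how a simple amine or a carboxylic acid at this aromatic carbon would compare with the formyl of compound 1, and whether this replacement would move the number the same way on another core.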